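This account rests on a few compounds, and the source may have more. Where it says the series, first, only, none or still open, it means among the compounds named here.

Compound 3 `Cc1ccc(S(=O)(=O)NCc2ccc(CNC(=O)c3cccnc3)cc2)cc1` carries a pyridin-3-yl group on a carbonyl carbon. In an assay on MDA-MB-231 cells for binding affinity to C-X-C chemokine receptor type 4 (Homo sapiens), read by immunofluorescence and microscopy, with stated times of 10 min and 30 min (on this read-out lower numbers stand for an effect already at smaller amounts and higher numbers for an effect only at larger amounts of compound), compound 3 gives only a limit of the assay, > 1000 nM (the limit of > 1000 nM in this assay, at which 1 of the 3 values shown sits). Two relatives with carbon-only rings on that carbonyl carbon have been measured as numbers: compound 1 `Cc1ccc(S(=O)(=O)NCc2ccc(CNC(=O)c3cccc(Cl)c3)cc2)cc1`, with 3-chlorophenyl, gives 100 nM in this assay, and compound 2 `Cc1ccc(S(=O)(=O)NCc2ccc(CNC(=O)c3ccccc3C)cc2)cc1`, with 2-methylphenyl, gives 100 nM. The step of an at least 10-fold higher number from compound 1 to compound 3 (1.00 log units; beyond the scatter) and the step of an at least 10-fold higher number from compound 2 to compound 3 (1.00 log units; beyond the scatter) both point the same way, while between the two carbon-only rings there is no change at the digits printed from compound 1 to compound 2 (within the scatter).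

Compound 4 `Cc1ccc(S(=O)(=O)NCc2ccc(CNC(=O)c3ccccc3Cl)cc2)cc1` has not yet been measured. It differs from compound 3 in one place: 2-chlorophenyl in place of pyridin-3-yl on a carbonyl carbon. The change returns to a carbon-only ring on the carbonyl carbon, the kind of ring found in compound 1 and compound 2, whereas compound 3 with its pyridin-3-yl ring gave only a limit. Both measured steps toward the pyridin-3-yl ring were at least modest and in the same direction, so the step in reverse is expected to be of similar size and the opposite sign: an at least 10-fold lower number from compound 3 to compound 4 (1.00 log units; beyond the scatter). Compound 4 is therefore estimated at 100 nM in this assay, with a range from 30 nM to 400 nM.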

Compound 4, effective concentration (reported as EC, without a stated level of effect): 10 nM
For compound 4 the middle estimate is 10-fold (1.00 log units) above the measured one, outside the stated range (below it).
By their numbers in this assay, from the lowest: compound 4; then compounds 1 and 2 (each within the scatter of the next). At a limit, above all of these: compound 3.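

Compounds 1 and 2 gave no sign that one carbon-only ring on the carbonyl carbon differs from another, but this position does separate them. With 2-chlorophenyl in place of 3-chlorophenyl, this assay shows a 10-fold lower number from compound 1 to compound 4 (1.00 log units; beyond the scatter), so where the chlorine sits on the ring matters, and with chloro in place of methyl on an aromatic carbon it shows a 10-fold lower number from compound 2 to compound 4 (1.00 log units; beyond the scatter), so the identity of that one group matters as well. The change from the pyridin-3-yl ring gives an at least 100-fold lower number from compound 3 to compound 4 (2.00 log units; beyond the scatter), and the true size of this step stays unknown, as compound 3 is a limit of the assay and not a number: the limit of > 1000 nM in this assay, at which 1 of the 4 values shown sits.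

On these data alone, whether chlorine itself is needed at this place stays open, since a 2-bromophenyl or a 2-methoxyphenyl ring would test how narrow the preference is. It also remains unclear how much of the gap to compound 3 comes from the ring nitrogen and how much from the missing chlorine, a question that a pyridine ring carrying a chlorine could help to settle.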